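The compounds below may be only part of what the source reports. "The series", "measured", "known", "first", "only" and "open" are said of these compounds alone.

Measured so far in a functional assay on MCF7 cells (Homo sapiens) for cytotoxicity; a higher number here means a weaker inhibitor, a lower number a stronger inhibitor:
Compound 1 `C=C/C=C\[C@H](C)[C@H](OC(N)=O)[C@@H](C)[C@H](O)[C@@H](C)C/C(C)=C\[C@H](C)[C@@H](O)[C@@H](C)/C=C\CCc1ccccc1` — in this assay compound 1 gives 560 nM.
Compound 2 `C=C/C=C\[C@H](C)[C@H](OC(N)=O)[C@@H](C)[C@H](O)[C@@H](C)C/C(C)=C\[C@H](C)[C@@H](O)[C@@H](C)/C=C\CCc1ccc(C)c(F)c1` — in this assay compound 2 gives 4000 nM.
Compound 3 `C=C/C=C\[C@H](C)[C@H](OC(N)=O)[C@@H](C)[C@H](O)[C@@H](C)C/C(C)=C\[C@H](C)[C@@H](O)[C@@H](C)/C=C\CCc1cccc(O)c1C` — in this assay compound 3 gives 1000 nM.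

Compound 3 stands second highest of the three numbers. Its nearest neighbour is compound 1, with a 1.8-fold higher number from compound 1 to compound 3 (0.25 log units; within the scatter); its furthest is compound 2, with a 4.0-fold lower number from compound 2 to compound 3 (0.60 log units; beyond the scatter).

Compound 4 `C=C/C=C\[C@H](C)[C@H](OC(N)=O)[C@@H](C)[C@H](O)[C@@H](C)C/C(C)=C\[C@H](C)[C@@H](O)[C@@H](C)/C=C\CCc1sccc1C` differs from compound 3 by 3-methylthiophen-2-yl in place of 3-hydroxy-2-methylphenyl on a saturated chain carbon, two bonds along the chain from a double-bonded chain carbon. Among the measured compounds shown here, no measured step swaps a six-membered ring for a five-membered one at this place, so the steps that bear on it are those that change the aryl group there: a 7.1-fold higher number from compound 1 to compound 2 (0.85 log units; beyond the scatter), a 1.8-fold higher number from compound 1 to compound 3 (0.25 log units; within the scatter) and a 4.0-fold lower number from compound 2 to compound 3 (0.60 log units; beyond the scatter). Changes at this position have so far ranged from within the scatter to a modest shift, in both directions, with only three compounds to judge by. For the measured compounds named here, with no closer precedent, the expected step is a 1.3-fold lower number from compound 3 to compound 4 (0.10 log units; within the scatter), that is, no step beyond the scatter, with the range widened to cover a modest move either way. Compound 4 is accordingly estimated at 800 nM, range 300 nM to 3000 nM.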

Compound 4, half-maximal inhibitory concentration: 620 nM
Compound 4: the middle estimate sits 1.3-fold (0.11 log units) above what was measured; low and high end bracket the measured number.
By their numbers in this assay, from the lowest: compounds 1, 4 and 3 (each within the scatter of the next); then compound 2.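

In this assay the five-membered sulfur-containing ring of 3-methylthiophen-2-yl is tolerated on this saturated chain carbon, two bonds along the chain from a double-bonded chain carbon: replacing phenyl gives a 1.1-fold higher number from compound 1 to compound 4 (0.04 log units; within the scatter) and replacing 3-hydroxy-2-methylphenyl gives a 1.6-fold lower number from compound 3 to compound 4 (0.21 log units; within the scatter) in the same series. Ring size and the hydroxy group therefore make no difference beyond the scatter across this swap, whereas replacing 3-fluoro-4-methylphenyl gives a 6.5-fold lower number from compound 2 to compound 4 (0.81 log units; beyond the scatter) and leaves compound 2 as the only one of the four set apart from the rest. Nothing measured here accounts for that separation.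

On these data alone, whether the fluoro or the methyl group of 3-fluoro-4-methylphenyl drives the shift remains open. Also open, as far as these compounds go, is how an aminomethyl or carboxylic acid group on the ring, or a longer chain before it, would read in this assay on this core.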